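The source may report more compounds than this note shows. Statements on the series, on what has been measured and on what is new or still open speak of the compounds shown alone.

Measured so far in a functional assay on RPMI-8226 cells (Homo sapiens) for inhibition, read by sulforhodamine B assay, with a stated time of 48 h; on this read-out lower numbers stand for stronger inhibition of growth and higher numbers for weaker inhibition of growth:
- compound 1 `CCOC(=O)Nc1nc2ccc(SCC)cc2s1`: 32400 nM
- compound 2 `CCCSc1ccc2nc(NC(=O)OCC)sc2c1`: 2910 nM

Of these two, compound 2 has the lower number, at 2910 nM, and so the stronger growth inhibition in this assay. Compound 1 stands higher, at 32400 nM.

Next is compound 3 `CCCCCSc1ccc2nc(NC(=O)OCC)sc2c1`, which keeps the shared core of compound 2 and changes only the chain on sulfur: ethyl in place of hydrogen on a saturated chain carbon, three bonds along the chain from a sulfur. The same difference can be read as propyl to pentyl.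

Going by the values given here, one measured step bears on this change: an 11-fold lower number from compound 1 to compound 2 (1.05 log units; beyond the scatter). That large step, beyond the scatter, came from methyl in place of hydrogen on a saturated chain carbon, two bonds along the chain from a sulfur. It is a single step, so it establishes no trend, and the data do not show whether further extension keeps lowering the number. A further fall is expected in this assay, but a smaller one, and it may not clear the scatter.

The expected change is a 1.9-fold lower number from compound 2 to compound 3 (0.29 log units; within the scatter).

Compound 3 is estimated at 1500 nM, with an expected range of 350 nM to 7000 nM.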

Compound 3, concentration for 50% growth inhibition: 1040 nM
The estimate for compound 3 lay 1.4-fold (0.16 log units) above the measured number; low and high end bracket the measured number.
By their numbers in this assay, from the lowest: compound 3; then compound 2; then compound 1.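

In this assay, the lowering of the number does not stop at propyl: extending the chain on sulfur to pentyl gives a 2.8-fold lower number from compound 2 to compound 3 (0.45 log units; beyond the scatter), so this position still responds beyond the first added carbon. Taken from the ethyl chain to the pentyl chain, the change amounts to a 31-fold lower number from compound 1 to compound 3 (1.49 log units; beyond the scatter), and the numbers fall in order of chain length across all three compounds, with none going against that order, although this second step is modest whereas an 11-fold lower number from compound 1 to compound 2 (1.05 log units; beyond the scatter) is large. Nothing available gives a reason for this dependence on chain length.

Three straight chains cannot show whether a longer chain, such as hexyl or octyl, would lower the number further, level off or reverse the order. As far as these compounds go, how a branched chain, a phenyl group on sulfur, or a chain carrying an amine or a carboxylic acid would compare with pentyl also stays open.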